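Trading nitro for fluoro on an aromatic carbon

The compounds below may be only part of what the source reports. "The series", "measured", "known", "first", "only" and "open" are said of these compounds alone.

Compounds followed in a functional assay on HCT-116 cells (Homo sapiens) for cytotoxicity, read by sulforhodamine B assay, with a stated time of 48 h; on this read-out higher numbers stand for weaker inhibition and lower numbers for stronger inhibition:
Compound 1 `CC(=O)n1nc(NC(=O)c2ccccc2)c2c1CN(C(=O)c1ccccc1)C2`: 580 nM
Compound 2 `CC(=O)n1nc(NC(=O)c2ccccc2)c2c1CN(C(=O)c1cccc([N+](=O)[O-])c1)C2`: 17300 nM
Compound 3 `CC(=O)n1nc(NC(=O)c2ccccc2)c2c1CN(C(=O)c1cccc(F)c1)C2`: not yet measured

Compound 2 holds the higher of the two numbers, at 17300 nM. The change to compound 3 is fluoro in place of nitro on an aromatic carbon, which puts fluoro in place of nitro on an aromatic carbon. Among the compounds with values here, one measured step bears on this: a 30-fold higher number from compound 1 to compound 2 (1.47 log units; beyond the scatter), with nitro in place of hydrogen. Within the data shown here, no fluoro compound has been measured, so compound 1 offers the only guide, and much of that large step is expected to reverse in this assay. The expected change is a 12-fold lower number from compound 2 to compound 3 (1.06 log units; beyond the scatter), towards a lower number. For compound 3 the estimated value is 1500 nM, with an expected range from 350 nM to 8000 nM.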

Compound 3, half-maximal inhibitory concentration: 21900 nM
Compound 3: middle estimate off by 15-fold (1.16 log units), on the low side; the whole stated range lies below it.
By their numbers in this assay, from the lowest: compound 1; then compounds 2 and 3 (each within the scatter of the next).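

In this assay, the 3-fluorophenyl of compound 3 and the 3-nitrophenyl of compound 2 cannot be told apart (a 1.3-fold higher number from compound 2 to compound 3 (0.10 log units; within the scatter)), whereas fluoro in place of hydrogen gives a large step (a 38-fold higher number from compound 1 to compound 3 (1.58 log units; beyond the scatter)). The large step seen with nitro at this place is therefore not confined to nitro, since fluoro separates from compound 1 just as far. Nothing available explains why these two groups read alike. Going by these compounds, whether an amine or a methoxy group here would stay close to compound 1 or read like nitro and fluoro remains open.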